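The source may report more compounds than this note shows. Statements on the series, on what has been measured and on what is new or still open speak of the compounds shown alone.

Values in a functional assay on A549 cells (Homo sapiens) for inhibition, read by MTT assay, with a stated time of 72 h; a lower number here means a stronger inhibitor, a higher number a weaker inhibitor:
Compound 1 `C=C(Cl)C(=O)Nc1cc(Nc2nc3c(c(-c4cn(C)c5ccc(F)cc45)n2)CSCC3)c(OC)cc1N(C)CCN(C)C`: 864 nM
Compound 2 `C/C=C\C(=O)Nc1cc(Nc2nc3c(c(-c4cn(C)c5ccc(F)cc45)n2)CSCC3)c(OC)cc1N(C)CCN(C)C`: 5310 nM

Of the two measured compounds in this assay, compound 2 has the higher number, 5310 nM, and so is the weaker inhibitor. Compound 3 `CC/C=C\C(=O)Nc1cc(Nc2nc3c(c(-c4cn(C)c5ccc(F)cc45)n2)CSCC3)c(OC)cc1N(C)CCN(C)C` differs from it by methyl in place of hydrogen on a saturated chain carbon bound to a double-bonded chain carbon, so prop-1-en-1-yl becomes but-1-en-1-yl. Among the compounds with values here, only one measured step touches this group, a 6.1-fold higher number from compound 1 to compound 2 (0.79 log units; beyond the scatter), and it was a different replacement, 1-chloroethenyl to prop-1-en-1-yl. Within the data shown here, no measured step shows the effect of this added methyl, so only a small change is expected, perhaps slightly weaker. The expected step is a 1.1-fold higher number from compound 2 to compound 3 (0.05 log units; within the scatter). The estimate for compound 3 is 6000 nM, with a range of 2500 nM to 14000 nM.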

Compound 3, half-maximal inhibitory concentration: 1450 nM
Compound 3: the middle estimate sits 4.1-fold (0.62 log units) above what was measured, outside the stated range (below it).
By their numbers in this assay, from the lowest: compounds 1 and 3 (each within the scatter of the next); then compound 2.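

In this assay, methyl in place of hydrogen on the saturated chain carbon bound to a double-bonded chain carbon gives a 3.7-fold lower number from compound 2 to compound 3 (0.56 log units; beyond the scatter) and so shows that this position responds to a single added carbon. With a 1.7-fold higher number from compound 1 to compound 3 (0.22 log units; within the scatter) as the step, but-1-en-1-yl on the carbonyl carbon matches 1-chloroethenyl, with no chlorine present. Nothing available explains these steps. The compounds shown leave open whether a longer chain or an amine such as dimethylamino at this carbon would lower the number further.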